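The source may report more compounds than this note shows. Statements on the series, on what has been measured and on what is new or still open speak of the compounds shown alone.

Working notes on the series.

For the measured compounds named here, compound 2 `CC(C)c1onc(-c2c(Cl)cccc2Cl)c1COc1ccc(-c2nc3ccc(C(=O)O)cc3n2C(C)C)cc1` stands lowest of the three numbers measured so far in an assay on Huh-7 cells for agonist activity at Bile acid receptor (Homo sapiens), read by a luciferase reporter; a lower number here means that less compound is needed, a higher number that more compound is needed for the effect: compound 2 gives 3.39 nM. Going by the values given here, compound 3 `CC(C)c1onc(-c2c(Cl)cccc2Cl)c1COc1ccc(-c2nc3ccc(C(=O)O)cc3n2CC2CC2)cc1`, which carries cyclopropylmethyl in place of isopropyl on the aromatic nitrogen, gives 19.4 nM; this is the one single-point step known, a 5.7-fold higher number from compound 2 to compound 3 (0.76 log units; beyond the scatter). Compound 1 `CC(C)c1onc(-c2c(Cl)cccc2Cl)c1COc1ccc(-c2nc3cc(C(=O)O)ccc3n2C)cc1` differs from compound 2 in more than one place and is not a single step; compound 1 gives 25.8 nM.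

Compound 4 `CCCn1c(-c2ccc(OCc3c(-c4c(Cl)cccc4Cl)noc3C(C)C)cc2)nc2ccc(C(=O)O)cc21` is the next change from compound 2: propyl in place of isopropyl on an aromatic nitrogen. Among the compounds with values here, the only step that bears on it is the one from compound 2 to compound 3, where a different three-carbon group on the same aromatic nitrogen gave a modest rise. Propyl is a chain rather than a branched or ring-bearing group, so a smaller rise than that one is expected, but a rise beyond the scatter is more likely than none: compound 4 is estimated at a 2.4-fold higher number from compound 2 to compound 4 (0.37 log units; beyond the scatter). Compound 4 is therefore expected to give about 8 nM, with a range from 3 nM to 25 nM.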

Compound 4, half-maximal effective concentration: 9.3 nM
Estimate against measurement, compound 4: 1.2-fold (0.07 log units) below; the measured number falls inside the stated range.
By their numbers in this assay, from the lowest: compound 2; then compound 4; then compounds 3 and 1 (each within the scatter of the next).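

In this assay, a 2.7-fold higher number from compound 2 to compound 4 (0.44 log units; beyond the scatter) comes with the same atoms on the aromatic nitrogen, so the way the three carbons are joined changes the number without any change in heavy-atom count. A second comparison, a 2.1-fold lower number from compound 3 to compound 4 (0.32 log units; beyond the scatter), separates propyl from cyclopropylmethyl beyond the scatter, which gives three distinct levels at this position: isopropyl lowest, propyl in the middle and cyclopropylmethyl highest. No measurement at hand accounts for these differences.

Still open is how a shorter ethyl chain, a longer butyl chain or a more branched tert-butyl group on this nitrogen would fit among these levels. Also open, as far as these compounds go, is whether the same order of the three groups would hold on the core of compound 1.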